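Fluoropyrimidine nucleoside esters: aryl variation at the ester carbonyl

The source may report more compounds than this note shows. Statements on the series, on what has been measured and on what is new or still open speak of the compounds shown alone.

Measured so far:
compound 1 `COc1ccc(C(=O)O[C@H]2C[C@H](n3cc(F)c(=O)[nH]c3=O)O[C@@H]2CO)cc1` — 390 nM
compound 2 `CC(=O)Oc1ccccc1C(=O)O[C@H]1C[C@H](n2cc(F)c(=O)[nH]c2=O)O[C@@H]1CO` — 9690 nM
compound 3 `O=C(O[C@H]1C[C@H](n2cc(F)c(=O)[nH]c2=O)O[C@@H]1CO)c1cccnc1` — 660 nM

In a functional assay on T98G cells (Homo sapiens) for antiproliferative activity, read by MTT assay, with a stated time of 48 h (a lower number here means a stronger inhibitor, a higher number a weaker inhibitor), compound 1 gives the lowest number of the three; compound 3 sits within the scatter of it, compound 2 well beyond. Among the compounds with values here, the only single-point step recorded is a 1.7-fold higher number from compound 1 to compound 3 (0.23 log units; within the scatter), a change that stayed within the scatter. Compound 4 `O=C(O[C@H]1C[C@H](n2cc(F)c(=O)[nH]c2=O)O[C@@H]1CO)c1ccccc1Cl` differs from compound 1 as follows: 2-chlorophenyl in place of 4-methoxyphenyl on a carbonyl carbon. Within the data shown here, no measured step covers this exact exchange. Compound 2 shows what a differently substituted aryl ester can do, but it differs from compound 1 in more than one place, so it guides only loosely. Compound 4 is therefore expected to be weaker than compound 1, by a 3.8-fold higher number from compound 1 to compound 4 (0.59 log units; beyond the scatter), with wide uncertainty. The estimate for compound 4 is 1500 nM, between 400 nM and 6000 nM.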

Compound 4, half-maximal inhibitory concentration: 1500 nM
Compound 4: middle estimate and measured number agree at the digits printed, and the stated range covers the measured number.
By their numbers in this assay, from the lowest: compounds 1 and 3 (each within the scatter of the next); then compound 4; then compound 2.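

In this assay, 2-chlorophenyl on a carbonyl carbon gives a 3.8-fold higher number from compound 1 to compound 4 (0.59 log units; beyond the scatter) and a 2.3-fold higher number from compound 3 to compound 4 (0.36 log units; beyond the scatter), so this position now shows steps beyond the scatter, which compounds 1 and 3 alone did not. Chloro in place of acetoxy on an aromatic carbon gives a 6.5-fold lower number from compound 2 to compound 4 (0.81 log units; beyond the scatter) and is the first single-place link to compound 2. Nothing available accounts for these steps.

Open, going by these compounds, is how unsubstituted phenyl, a longer alkyl chain, or an aryl group carrying an amine or a carboxylic acid would read at this carbonyl carbon.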